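Hydroxy for Piperidine on a Sulfonamide Thioester Series

The compounds below may be only part of what the source reports. "The series", "measured", "known", "first", "only" and "open" are said of these compounds alone.

This account follows a small set of compounds built on a shared core, measured in a functional assay on HCT-116 cells (Homo sapiens) for cytotoxicity; on this read-out higher numbers stand for an effect only at larger amounts of compound and lower numbers for an effect already at smaller amounts. Compound 1 `CC(=O)SCC(=O)c1ccc(NS(=O)(=O)c2ccc(OCCCN3CCCCC3)cc2)nc1` gives 1000 nM in this assay. Compound 2 `CC(=O)SCC(=O)c1ccc(NS(=O)(=O)c2ccc3c(c2)COOC3)nc1`, which carries a different substituent on the sulfonyl ring, gives 1200 nM in this assay. Of the two numbers shown, compound 1 has the lower one, but its gap to compound 2 lies within the usual scatter of repeated measurements, so the two compounds cannot be told apart on this read-out.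

Compound 3 `CC(=O)SCC(=O)c1ccc(NS(=O)(=O)c2ccc(OCCCO)cc2)nc1` has not yet been measured. It differs from compound 1 in one place: hydroxy in place of piperidin-1-yl on a saturated chain carbon, three bonds along the chain from an oxygen on an aromatic ring. Among the compounds with values here, no step between measured compounds shows how this assay responds to such a change. Within the data shown here, since the two values in hand sit within scatter of each other, the series so far gives no sign of large swings. The expectation for compound 3 is therefore a step of a 1.5-fold higher number from compound 1 to compound 3 (0.18 log units; within the scatter), a modest rise at most. Compound 3 is estimated at 1500 nM, with a range from 600 nM to 4000 nM.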

Compound 3, half-maximal effective concentration: 8600 nM
Compound 3: middle estimate off by 5.7-fold (0.76 log units), on the low side; the measured number lies above the stated range.
By their numbers in this assay, from the lowest: compounds 1 and 2 (each within the scatter of the next); then compound 3.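

Within the data shown here, putting hydroxy in place of piperidin-1-yl on a saturated chain carbon, three bonds along the chain from an oxygen on an aromatic ring, gives the only readable step in this assay, namely an 8.6-fold higher number from compound 1 to compound 3 (0.93 log units; beyond the scatter) and thus beyond the scatter. This shows that the read-out is not indifferent to what this chain carries, as the change from the piperidine ring to a lone hydroxy means that the cytotoxic effect appears only at larger amounts of compound. Nothing measured here bears on why the number rises, so this single step cannot assign it to the loss of the ring, the loss of the nitrogen or the arrival of the hydroxy hydrogen-bond donor.

The compounds shown leave open whether the ring or the nitrogen matters more, a question that an open-chain amine such as dimethylamino or a morpholine in the same place could help to settle. They also leave open how a carboxylic acid on this chain, or a longer chain carrying the piperidine, would read, so the finding holds for this one pair only.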